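The source may report more compounds than this note shows. Statements on the series, on what has been measured and on what is new or still open speak of the compounds shown alone.

Measured compounds:
- Compound 1, `CNc1cc(Oc2ccc(NC(=O)Nc3cccc(CF)c3)cc2)ncn1`: 400 nM
- Compound 2, `C[C@@H](O)CNc1cc(Oc2ccc(NC(=O)Nc3cccc(C(F)(F)F)c3)cc2)ncn1`: 63 nM

Both compounds were tested in an assay on isolated protein for inhibition of serine/threonine-protein kinase TNNI3K (Homo sapiens); a higher number here means a weaker inhibitor, a lower number a stronger inhibitor. Of the two numbers, compound 2 gives the lower one, 63 nM, while compound 1 gives 400 nM, and the gap between them lies beyond the usual scatter. The two structures differ in more than one place, so the pair by itself does not show which change carries the gap.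

Compound 3, `O=C(Nc1ccc(Oc2ccncn2)cc1)Nc1cccc(C(F)(F)F)c1`, has not yet been measured. It differs from compound 2 in one place: hydrogen in place of (2-hydroxypropyl)amino on an aromatic carbon. The (2-hydroxypropyl)amino group is thus removed and nothing takes its place.

Since compound 2 holds the lowest value, 63 nM, removing a whole group from it is expected to move the number upward by a moderate step, a 4.8-fold higher number from compound 2 to compound 3 (0.68 log units; beyond the scatter). Compound 3 is therefore estimated at 300 nM, within a range of 100 nM to 1000 nM.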

Compound 3, half-maximal inhibitory concentration: 160 nM
For compound 3 the middle estimate is 1.9-fold (0.27 log units) above the measured one; the measured number falls inside the stated range.
By their numbers in this assay, from the lowest: compound 2; then compound 3; then compound 1.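

Replacing the (2-hydroxypropyl)amino group with hydrogen on this aromatic carbon gives in this assay a 2.5-fold higher number from compound 2 to compound 3 (0.40 log units; beyond the scatter) as a modest step beyond the scatter. This shows that the group itself changes the number, which the earlier pair could not show, as those compounds differ in more than one place. Yet the group is not required for a measurable result, since compound 3 still gives 160 nM with only hydrogen there, and no measurement shown here explains the step.

It remains open which part of the (2-hydroxypropyl)amino group accounts for the step: the hydroxyl, the chain or the nitrogen joined to the ring. A plain amino group, a propylamino chain without the hydroxyl, or the opposite stereoisomer at this position would help to separate these parts.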